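Trimethoxyphenyl in Place of Fluorophenyl on a Pyrazoline Core

The source may hold more compounds than are shown below. What is called first, only, known or untested is meant among the compounds shown, and "the series" means these compounds.

Measured compounds and their numbers in a functional assay on HepG2 cells (Homo sapiens) for antiproliferative activity, read by MTT assay, with a stated time of 24 h; on this read-out higher numbers stand for weaker inhibition and lower numbers for stronger inhibition:
Compound 1, `Fc1ccc(C2CC(c3ccccc3)=NN2c2ccc(-c3ccccc3)nn2)cc1`, gives 8420 nM.
Compound 2, `COc1ccc(C2CC(c3ccccc3)=NN2c2ccc(-c3ccccc3)nn2)cc1`, reaches only the limit of the assay, > 100000 nM.
Compound 3, `Fc1ccc(C2CC(c3ccc(Cl)cc3)=NN2c2ccc(-c3ccccc3)nn2)cc1`, gives 10000 nM.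

Compound 3 has the highest of the two numbers shown; the nearest is compound 1, and that gap, a 1.2-fold higher number from compound 1 to compound 3 (0.07 log units; within the scatter), lies within the scatter, so the two are not told apart. The step to compound 4, `COc1cc(C2CC(c3ccc(Cl)cc3)=NN2c2ccc(-c3ccccc3)nn2)cc(OC)c1OC`, is 3,4,5-trimethoxyphenyl in place of 4-fluorophenyl on a saturated ring carbon.

Among the measured compounds shown here, one measured step bears on this change: an at least 11-fold higher number from compound 1 to compound 2 (1.07 log units; beyond the scatter), which swapped a single fluoro for a single methoxy at the same phenyl and pushed the number up to the limit (the limit of > 100000 nM in this assay, at which 1 of the 3 values shown sits). Compound 4 adds three methoxy groups at that position, so a step of that kind, towards weaker inhibition, is expected. A rise of about a 5.0-fold higher number from compound 3 to compound 4 (0.70 log units; beyond the scatter) is estimated, with a real chance that only a limit is recorded. Compound 4 is therefore expected to give about 50000 nM, somewhere between 10000 nM and 150000 nM.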

Compound 4, half-maximal inhibitory concentration: > 100000 nM
Compound 4 gave a limit, no number; the forecaster's own chance of this, stated with the estimate: 40%; at least 2.0-fold (0.30 log units) between middle value and limit.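

Replacing 4-fluorophenyl with 3,4,5-trimethoxyphenyl on the saturated ring carbon gives an at least 10-fold higher number from compound 3 to compound 4 (1.00 log units; beyond the scatter) in this assay, so the loss seen earlier with a single methoxy group also appears with three methoxy groups and on a compound carrying a 4-chlorophenyl group. From the compounds shown here alone, compound 4 records only a limit, > 100000 nM, so the true size of this step remains unknown. Together with compound 2, this means that neither methoxy-bearing compound shown gives a measurable number: the limit of > 100000 nM in this assay, at which 2 of the 4 values shown sit.

Going by these compounds, it remains open how far beyond the limit either methoxy-bearing compound lies, and whether one or two methoxy groups on the compound with the 4-chlorophenyl group would behave the same way. Also open, on these data alone, is how a hydroxyl, an amine or a carboxylic acid on this phenyl ring would compare with fluoro.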